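This account rests on a few compounds, and the source may have more. Where it says the series, first, only, none or still open, it means among the compounds named here.

Of the compounds shown here, three have so far been tested in a functional assay on HepG2 cells (Homo sapiens) for cytotoxicity, read by MTT assay, with a stated time of 24 h; on this read-out lower numbers stand for stronger inhibition and higher numbers for weaker inhibition. Compound 1 (`CC(=O)Nc1ccc(S(=O)(=O)N2C/C(=C\c3ccccc3F)C(=O)/C(=C/c3ccccc3F)C2)cc1`) gives 5840 nM, compound 2 (`CC(=O)Nc1ccc(S(=O)(=O)N2C/C(=C\c3cccc([N+](=O)[O-])c3)C(=O)/C(=C/c3cccc([N+](=O)[O-])c3)C2)cc1`) gives 7140 nM, and compound 3 (`O=C1/C(=C/c2cccc([N+](=O)[O-])c2)CN(S(=O)(=O)c2ccc(F)cc2)C/C1=C\c1ccccc1F`) gives 7040 nM. These numbers all lie within the usual scatter of repeated measurements, so compound 3 stands level with the other two, and no ranking can be read from them.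

The next compound to be tested, compound 4 (`CC(=O)Nc1ccc(S(=O)(=O)N2C/C(=C\c3cccc([N+](=O)[O-])c3)C(=O)/C(=C/c3ccccc3F)C2)cc1`), differs from compound 3 in one place. It has acetamido in place of fluoro on an aromatic carbon, para to a large group: acetamido in place of fluoro on an aromatic carbon. Among the measured compounds shown here, no two tested compounds differ in a single place, so this swap has no direct precedent in the data. The nearest evidence is indirect. Compound 1, at 5840 nM, and compound 2, at 7140 nM, both carry the acetamido group that compound 4 will carry, yet their numbers do not separate from that of compound 3, at 7040 nM, which carries fluoro.

On that basis, no step beyond the scatter is expected in this assay. The expected step is a 1.1-fold lower number from compound 3 to compound 4 (0.03 log units; within the scatter), with no clear direction. For compound 4, the estimated value is 6500 nM, with an expected range of 3500 nM to 12000 nM.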

Compound 4, half-maximal inhibitory concentration: 8800 nM
Estimate against measurement, compound 4: 1.4-fold (0.13 log units) below, within the range that was stated.
By their numbers in this assay, from the lowest: compounds 1, 3, 2 and 4 (each within the scatter of the next).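

In this assay, acetamido in place of fluoro on an aromatic carbon, para to a large group, gives a 1.3-fold higher number from compound 3 to compound 4 (0.10 log units; within the scatter) and so stays within the scatter: this first direct test of the change from 4-fluorophenyl to 4-acetamidophenyl does not separate the two compounds. Among the compounds shown here, compound 4 also provides the first single-place comparisons on a double-bonded chain carbon bound to a double-bonded ring carbon, where 2-fluorophenyl in place of 3-nitrophenyl gives a 1.2-fold higher number from compound 2 to compound 4 (0.09 log units; within the scatter) and 3-nitrophenyl in place of 2-fluorophenyl gives a 1.5-fold higher number from compound 1 to compound 4 (0.18 log units; within the scatter) with both steps also within the scatter. No measurement shown here offers an explanation for these small steps.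

The compounds shown leave open whether a different group on that aromatic carbon, such as an amine or a carboxylic acid, would produce a step beyond the scatter. They also leave open whether a plain phenyl or a 4-methoxyphenyl on the double-bonded chain carbon would separate from the 2-fluorophenyl and 3-nitrophenyl groups compared here.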